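Urea series: bromo replacing hexyl on the aromatic carbon

The source may hold more compounds than are shown below. What is called first, only, known or untested is meant among the compounds shown, and "the series" means these compounds.

Measured so far in an ADME assay on the whole organism with Oryza sativa as the target, tested at 10 uM; on this read-out higher numbers stand for a weaker effect at the one concentration tested and lower numbers for a stronger effect:
compound 1, `CC(C)c1ccc(NC(=O)N[C@H](C)c2ccccc2)cc1`, gives 49%
compound 2, `CCCCCCc1ccc(NC(=O)N[C@H](C)c2ccccc2)cc1`, gives 101%
compound 3, `CCCCCCc1ccc(NC(=O)N[C@@H](C)c2ccccc2)cc1`, gives 99%

Compound 2 gives the largest of the three numbers in this assay, with compound 3 within the scatter of it and compound 1 well below. Among the measured compounds shown here, the one substantial step measured is a number 52 percentage points higher from compound 1 to compound 2 (beyond the scatter), which shows that the group on the aromatic carbon moves the read-out strongly. The step of a number 2 percentage points lower from compound 2 to compound 3 (within the scatter) is flat, which fits (the fact that compounds 2 and 3 differ only in the configuration as drawn).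

Compound 4, `C[C@@H](NC(=O)Nc1ccc(Br)cc1)c1ccccc1`, is to be measured in this assay. It differs from compound 2 by bromo in place of hexyl on an aromatic carbon. For the measured compounds named here, the only step that bears on this change is the one between compound 1 and compound 2: lengthening the chain from isopropyl to hexyl raised the number by a number 52 percentage points higher from compound 1 to compound 2 (beyond the scatter). Bromo is a single heavy atom, smaller even than isopropyl, so the change is expected to run the other way and to reach or exceed the size of that step. Compound 4 is therefore expected at 50%, with a range of 25% to 80%, meaning an expected step of a number 51 percentage points lower from compound 2 to compound 4 (beyond the scatter).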

Compound 4, a percentage reported as activity, at one concentration (the size of the read-out at that concentration, not a potency): 87%
Estimate against measurement, compound 4: 37 percentage points below; measured number outside the range, above it.
By their numbers in this assay, from the lowest: compound 1; then compound 4; then compounds 3 and 2 (each within the scatter of the next).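

In this assay bromo in place of hexyl on the aromatic carbon gives a number 14 percentage points lower from compound 2 to compound 4 (beyond the scatter) and is a modest step, while bromo in place of isopropyl gives a number 38 percentage points higher from compound 1 to compound 4 (beyond the scatter) and is a large one. The number at this position therefore does not fall in step with the heavy-atom count of the group: compound 4, with its single heavy atom against the six of hexyl, stays closer to compound 2 than to compound 1, and compound 1 keeps the lowest number of the series. Nothing measured on these compounds bears on why the three groups fall in this order.

Open, as far as these compounds go, is how an amine, a carboxylic acid, a methoxy group or a butyl chain on the same aromatic carbon would place in this order, and whether the number climbs gradually or abruptly as the chain grows from isopropyl to hexyl. Also open, from the compounds shown here alone, is whether the flat response to configuration seen with hexyl holds with bromo or isopropyl on the ring.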